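This account rests on a few compounds, and the source may have more. Where it says the series, first, only, none or still open, it means among the compounds named here.

Measured so far:
compound 1 `CCc1ccc2[nH]c(=O)c(CN(Cc3ccc(F)cc3)Cc3ccc(C(C)(C)C)cc3)cc2c1` — > 33000 nM
compound 2 `CCCc1ccc2[nH]c(=O)c(CN(Cc3ccc(F)cc3)Cc3ccc(C(C)(C)C)cc3)cc2c1` — 8400 nM
compound 3 `Cc1ccc2[nH]c(=O)c(CN(Cc3cccc(F)c3)Cc3ccc4ccccc4c3)cc2c1` — > 5000 nM

The three compounds were tested in a toxicity assay on MDCK cells (Canis lupus familiaris) for cytotoxicity, read by crystal violet staining, with a stated time of 48 h; a higher number here means that more compound is tolerated, a lower number that less compound is tolerated. For compound 1 the value > 33000 nM is a limit of the assay and not a number (the limit of > 33000 nM in this assay, at which 1 of the 3 values shown sits). Compound 2 gives 8400 nM in this assay. The change between them, (methyl in place of hydrogen on a saturated chain carbon, two bonds along the chain from an aromatic carbon), gives an at least 3.9-fold lower number from compound 1 to compound 2 (0.59 log units; beyond the scatter). For compound 3 the value > 5000 nM is likewise a limit and not a number (the limit of > 5000 nM in this assay, at which 1 of the 3 values shown sits). The difference between the core of compound 1 and the core of compound 3 is not broken down here.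

Compound 4 `CCc1ccc2[nH]c(=O)c(CN(Cc3cccc(F)c3)Cc3ccc4ccccc4c3)cc2c1` has not yet been measured in this assay. It differs from compound 3 by methyl in place of hydrogen on a saturated chain carbon bound to an aromatic carbon. This is the same kind of change as that from compound 1 to compound 2, though not the same: there the methyl entered on a saturated chain carbon two bonds along the chain from an aromatic carbon, here it enters on a saturated chain carbon bound to an aromatic carbon, and the cores differ as well. Resting on an at least 3.9-fold lower number from compound 1 to compound 2 (0.59 log units; beyond the scatter), compound 4 is expected to show a step that the limit leaves unreadable from compound 3 to compound 4, a lower number than compound 3, with wide uncertainty since the value of compound 3 is itself a limit. The estimate for compound 4 in this assay is 6000 nM, expected to lie between 2000 nM and 30000 nM.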

Compound 4, half-maximal cytotoxic concentration: > 5000 nM
Compound 4 was reported as a limit; the forecaster's own chance of this, stated with the estimate: 40%; the middle value does not contradict the limit.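

In this assay compound 4 gives > 5000 nM, which is a limit of the assay and not a number. Compound 3 gives > 5000 nM, also a limit, so no step can be read between these two compounds. The compounds shown leave open whether methyl in place of hydrogen on a saturated chain carbon bound to an aromatic carbon changes how much compound is tolerated.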